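Hydroxyamino Side Chain on a Fluoroindole Myeloperoxidase Inhibitor

The compounds below may be only part of what the source reports. "The series", "measured", "known", "first", "only" and "open" are said of these compounds alone.

Compound 1 `N#CCCCc1c[nH]c2ccc(F)cc12`: 72 nM
Compound 2 `NCC(N)CCc1c[nH]c2ccc(F)cc12`: 26 nM

In an assay on isolated protein for inhibition of Myeloperoxidase (Homo sapiens), read by ELISA, with a stated time of 5 min (a higher number here means a weaker inhibitor, a lower number a stronger inhibitor), compound 1 gives 72 nM, and compound 2 gives 26 nM. Compound 2 stands lowest of the two measured values, its nearest neighbour being compound 1 at a higher number. Among the measured compounds shown here, the only measured step, a 2.8-fold lower number from compound 1 to compound 2 (0.44 log units; beyond the scatter), links the nitrile side chain to the diamine side chain on the shared core.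

Compound 3 `ONCCCc1c[nH]c2ccc(F)cc12` carries the change ((hydroxyamino)methyl in place of 1,2-diaminoethyl on a saturated chain carbon, two bonds along the chain from an aromatic carbon). For the measured compounds named here, no measured step covers the exchange of a diamine for a hydroxyamino group, so the one step that bears on it at all is a 2.8-fold lower number from compound 1 to compound 2 (0.44 log units; beyond the scatter), which shows that the side chain two bonds from the aromatic carbon can move this assay by a modest amount. On that basis compound 3 is expected to sit close to compound 2, with the step of a 1.5-fold higher number from compound 2 to compound 3 (0.19 log units; within the scatter) expected to stay near the scatter. Compound 3 is estimated at 40 nM, within a range of 12 nM to 130 nM.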

Compound 3, half-maximal inhibitory concentration: 21 nM
Compound 3: middle estimate off by 1.9-fold (0.28 log units), on the high side; low and high end bracket the measured number.
By their numbers in this assay, from the lowest: compounds 3 and 2 (each within the scatter of the next); then compound 1.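

In this assay, (hydroxyamino)methyl in place of 1,2-diaminoethyl gives a 1.2-fold lower number from compound 2 to compound 3 (0.09 log units; within the scatter) and so leaves the two side chains indistinguishable at this position, although they differ in their atoms and match in their counts of hydrogen-bond donors and acceptors. Against the nitrile, hydroxyamino in place of cyano gives a 3.4-fold lower number from compound 1 to compound 3 (0.54 log units; beyond the scatter) as a second modest step alongside a 2.8-fold lower number from compound 1 to compound 2 (0.44 log units; beyond the scatter) in the same direction, so among these three compounds both replacements of the nitrile side chain lower the number by a modest amount. Nothing available explains why these side chains give these numbers.

The compounds shown leave open how a simple primary amine or a carboxylic acid would read at this position. They also leave open whether a longer chain carrying the hydroxyamino group would hold the number.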